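A few compounds are considered here, and "the series" means these few. Any claim that something is new, unique, unknown or untested is made for them only; others in the source may bear on it.

Three compounds share one core and differ only in the group on the carbonyl carbon of their amide. Compound 1 `C=C(C)C(=O)Nc1cc2c(N3CCc4ccccc43)ncnc2cc1OC` carries 1-methylethenyl there, and in a functional assay on PC-3 cells (Homo sapiens) for antiproliferative activity, read by MTT assay, with a stated time of 72 h (a higher number here means a weaker inhibitor, a lower number a stronger inhibitor), compound 1 gives 4830 nM. Compound 2 `COc1cc2ncnc(N3CCc4ccccc43)c2cc1NC(=O)C=C(C)C` carries 2-methylprop-1-en-1-yl, and in this assay compound 2 gives 7840 nM. Compound 3 `C/C=C/C(=O)Nc1cc2c(N3CCc4ccccc43)ncnc2cc1OC` carries prop-1-en-1-yl, and in this assay compound 3 gives 8120 nM. On these numbers compound 2 falls in the middle of the three, yet every step among them stays inside the scatter: a 1.6-fold higher number from compound 1 to compound 2 (0.21 log units; within the scatter), a 1.7-fold higher number from compound 1 to compound 3 (0.23 log units; within the scatter) and a 1.0-fold higher number from compound 2 to compound 3 (0.02 log units; within the scatter).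

Compound 4 `CC(C)=CC(=O)Nc1cc2c(N3CCc4ccccc43)ncnc2cc1O[C@@H]1CCOC1` keeps the amide group of compound 2 and changes a different part of the molecule: oxolan-3-yl in place of methyl on an oxygen on an aromatic ring. Among the compounds with values here, no measured step touches this oxygen; each step seen so far alters the group on the carbonyl carbon, and none of them moved the number beyond the scatter. The data thus give no direct guide for this change, and the expectation in this assay is a step of a 1.1-fold lower number from compound 2 to compound 4 (0.05 log units; within the scatter) that stays within the scatter, with a wide range to reflect the missing precedent. On that basis compound 4 is estimated at 7000 nM, between 2500 nM and 20000 nM.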

Compound 4, half-maximal inhibitory concentration: 4620 nM
The estimate for compound 4 lay 1.5-fold (0.18 log units) above the measured number, within the range that was stated.
By their numbers in this assay, from the lowest: compounds 4, 1, 2 and 3 (each within the scatter of the next).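

Within the data shown here, this is the first look at the oxygen on an aromatic ring, since all the earlier compounds carry methyl there and differ only at the amide. Measured in this assay, replacing methoxy with (oxolan-3-yl)oxy gives a 1.7-fold lower number from compound 2 to compound 4 (0.23 log units; within the scatter), so a much larger group, with a five-membered non-aromatic ring, a further hydrogen-bond acceptor and a defined stereocentre, leaves the number within the scatter at this position. Nothing shown explains why this change makes so little difference to the reading.

The compounds shown leave open whether the result depends on the ring and its oxygen or whether other groups on this oxygen, such as a longer chain like n-butyl, a chain ending in an amine like 2-(dimethylamino)ethyl, or the mirror-image form of oxolan-3-yl, would also stay within the scatter. They also leave open whether oxolan-3-yl would behave the same way with the 1-methylethenyl or prop-1-en-1-yl amide groups, as it appears here only with 2-methylprop-1-en-1-yl on the carbonyl carbon.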